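A few compounds are considered here, and "the series" means these few. Any claim that something is new, unique, unknown or untested is made for them only; others in the source may bear on it.

Compound 2 `CN(C)CCn1cnnc1-c1cc(Oc2ccc(NC(=O)N/N=C/c3c(O)ccc4ccccc34)cc2F)ccn1` carries a dimethylaminoethyl-substituted core linked through a urea-hydrazone to a 2-hydroxynaphthalen-1-yl group. In a functional assay on U-87MG ATCC cells (Homo sapiens) for cytotoxicity, read by MTT assay, with a stated time of 72 h (a higher number here means a weaker inhibitor, a lower number a stronger inhibitor), compound 2 gives 620 nM, the lowest of the three numbers recorded. Its closest neighbour in structure, compound 1 `CN(C)CCn1cnnc1-c1cc(Oc2ccc(NC(=O)N/N=C/c3cccc(Cl)c3Cl)cc2F)ccn1`, bears 2,3-dichlorophenyl at the same carbon and in this assay compound 1 gives 13200 nM; the step of a 21-fold lower number from compound 1 to compound 2 (1.33 log units; beyond the scatter) is large and beyond the scatter. Among the compounds with values here, compound 3 `Cn1cnnc1-c1cc(Oc2ccc(NC(=O)N/N=C/c3ccccc3)cc2F)ccn1`, with a plain phenyl and a methyl on the core, gives 36300 nM in this assay, and no single-change step links it to compound 2.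

Compound 4 `CN(C)CCn1cnnc1-c1cc(Oc2ccc(NC(=O)N/N=C/c3ccc(Cl)cc3Cl)cc2F)ccn1` is related to compound 2 by one change: 2,4-dichlorophenyl in place of 2-hydroxynaphthalen-1-yl on a carbon with a double bond to nitrogen. Within the data shown here, the only measured step that bears on it is the one from compound 1 to compound 2, where swapping a dichlorophenyl for the hydroxynaphthyl lowered the number sharply. Compound 4 reverses that kind of swap, returning to a dichlorophenyl, so a step upward of comparable size is expected, putting compound 4 near compound 1. The expected step for compound 4 is a 16-fold higher number from compound 2 to compound 4 (1.21 log units; beyond the scatter). Compound 4 is therefore estimated at 10000 nM in this assay, with a range from 3000 nM to 30000 nM.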

Compound 4, half-maximal inhibitory concentration: 2330 nM
For compound 4 the middle estimate is 4.3-fold (0.63 log units) above the measured one; the whole stated range lies above it.
By their numbers in this assay, from the lowest: compound 2; then compound 4; then compound 1; then compound 3.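

Within the dichlorophenyl pair, where the chlorines sit on the ring changes the result: in this assay the change gives a 5.7-fold lower number from compound 1 to compound 4 (0.75 log units; beyond the scatter) and this is the first sign that two groups with the same atoms can differ at this carbon with a double bond to nitrogen. It also changes how the 2-hydroxynaphthalen-1-yl group should be read, since the earlier comparison with 2,3-dichlorophenyl showed a large step, whereas 2,4-dichlorophenyl gives only a 3.8-fold higher number from compound 2 to compound 4 (0.57 log units; beyond the scatter) and so leaves compound 2 with the lowest number of the four, but by a modest margin. No measurement shown here accounts for either step.

The compounds shown leave open whether the step to compound 2 belongs to the hydroxyl or to the second aromatic ring, which a naphthyl group without the hydroxyl or a phenyl ring bearing one hydroxyl could separate. Going by these compounds, it also remains open how a single chlorine, a methoxy group or an amine on the phenyl ring would compare at this carbon on the dimethylaminoethyl-bearing core.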